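A few compounds are considered here, and "the series" means these few. Any claim that something is new, unique, unknown or untested is made for them only; others in the source may bear on it.

Compound 1, `COc1cc(N)c(Cl)cc1NC(=O)C1CCN(Cc2cccc(C#N)c2)CC1`, stands at a limit rather than at a number in a functional assay on the whole organism for antagonist activity, with Mus musculus as the target; a higher number here means that more compound is needed for the effect, a lower number that less compound is needed. In this assay compound 1 gives > 4 mg/kg, which is a limit of the assay. Compound 2, `COc1cc(N)c(Cl)cc1NC(=O)C1CCN(Cc2cccc(Cl)c2)CC1`, likewise reaches only a limit: in this assay compound 2 gives > 4 mg/kg. Compound 3, `COc1cc(N)c(Cl)cc1NC(=O)C1CCN(CC2CCC2)CC1`, also returns a limit, and in this assay compound 3 gives > 10 mg/kg. Because the three results are limits, the steps a step that the two limits leave unreadable from compound 1 to compound 2, a step that the two limits leave unreadable from compound 1 to compound 3 and a step that the two limits leave unreadable from compound 2 to compound 3 cannot be read; what can be said is that the limit of > 4 mg/kg in this assay, at which 2 of the 3 values shown sit, and (the limit of > 10 mg/kg in this assay, at which 1 of the 3 values shown sits).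

Compound 4, `CCCN1CCC(C(=O)Nc2cc(Cl)c(N)cc2OC)CC1`, carries the change (ethyl in place of 3-cyanophenyl on a saturated chain carbon bound to an amine nitrogen in a ring); cut one bond further out, this reads as 3-cyanobenzyl to propyl. The step from compound 1 to compound 3 bears most on it, since there too a ring of carbon only is exchanged for a small saturated group on the same chain carbon, and compound 3 stayed at a limit. Among the measured compounds shown here, no measured step gives a readable size, so no direction can be expected beyond the scatter; the expectation is that compound 4 also remains at or past the limit of the assay. Compound 4 is therefore estimated at 15 mg/kg, within 4 mg/kg to 60 mg/kg, which would mean an expected step that the limit leaves unreadable from compound 1 to compound 4.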

Compound 4, dose for half-maximal effect: > 10 mg/kg
Compound 4 gave a limit, no number; the forecaster's own chance of this, stated with the estimate: 75%; the middle value is on the limit's open side.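

Compound 4 gives > 10 mg/kg in this assay and this is a limit of the assay. Among the compounds shown here, no step from compound 1, compound 2 or compound 3 to compound 4 can be read, and compound 4 shares its limit with compound 3: the limit of > 10 mg/kg in this assay, at which 2 of the 4 values shown sit. The compounds shown leave open what dose of any of the four gives the half-maximal effect, and whether exchanging these groups changes that dose at all.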